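This account rests on a few compounds, and the source may have more. Where it says the series, first, only, none or still open, it means among the compounds named here.

Values in a functional assay on SW480 cells (Homo sapiens) for cytotoxicity, read by MTT assay, with a stated time of 48 h; on this read-out higher numbers stand for weaker inhibition and lower numbers for stronger inhibition:
- Compound 1 `COc1cc([C@@H]2C[C@]2(CO)C(=O)NCc2ccc(C)cc2)cc(OC)c1OC`: 26800 nM
- Compound 2 `CCOC(=O)[C@@]1(C(=O)NCc2ccc(C)cc2)C[C@H]1c1cc(OC)c(OC)c(OC)c1`: > 100000 nM (a limit of the assay, not a number)
- Compound 3 `COc1cc([C@H]2C[C@]2(CO)C(=O)NCc2ccc(C)cc2)cc(OC)c1OC`: 94000 nM

Of the two values that are true numbers, the higher belongs to compound 3, at 94000 nM. Its nearest neighbour is compound 1, at 26800 nM.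

Next in view is compound 4 `COc1cc([C@@H]2C[C@@]2(CO)C(=O)NCc2ccc(C)cc2)cc(OC)c1OC`. Its relation to compound 3 is as follows: the two compounds have the same atoms and bonds and differ only in configuration as drawn: 2 of 2 stereo elements differ (all stereocentres are inverted: mirror images); a stereocentre at a saturated ring carbon is drawn R in compound 3 and S in compound 4; a stereocentre at a saturated ring carbon is drawn S in compound 3 and R in compound 4. No group leaves or enters, and the two compounds are mirror images.

Among the measured compounds shown here, only one measured step bears on this change: a 3.5-fold higher number from compound 1 to compound 3 (0.54 log units; beyond the scatter). That step is modest, yet it lies beyond the scatter, and it comes with the fact that compounds 1 and 3 differ only in the configuration as drawn. In this small set, then, configuration alone has moved the reading, although in that step only one of the two stereo elements differs. For the measured compounds named here, no measured step inverts both.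

A step of similar modest size is therefore expected in this assay. The direction is more likely towards a lower number, since compound 3 at 94000 nM already holds the higher of the two numbers. This direction remains uncertain.

The expected change is a 2.1-fold lower number from compound 3 to compound 4 (0.32 log units; beyond the scatter).

For compound 4 the estimated value is 45000 nM, with an expected range of 15000 nM to 110000 nM.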

Compound 4, half-maximal inhibitory concentration: 76300 nM
The estimate for compound 4 lay 1.7-fold (0.23 log units) below the measured number; measured number inside the range.
By their numbers in this assay, from the lowest: compound 1; then compounds 4 and 3 (each within the scatter of the next). At a limit, above all of these: compound 2.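

In this assay the inversion of both stereocentres gives a 1.2-fold lower number from compound 3 to compound 4 (0.09 log units; within the scatter), so this mirror-image pair is not separated, a case the earlier single-centre step could not show. Compound 1 stands apart from both: the step of a 2.8-fold higher number from compound 1 to compound 4 (0.45 log units; beyond the scatter) sits with a 3.5-fold higher number from compound 1 to compound 3 (0.54 log units; beyond the scatter), so inverting either single stereocentre of compound 1 gives a step beyond the scatter, and configuration alone moves the reading in this set: the fact that compounds 1 and 4 differ only in the configuration as drawn. Hydroxymethyl in place of ethoxycarbonyl on a saturated ring carbon gives an at least 1.3-fold lower number from compound 2 to compound 4 (0.11 log units; that floor lies within the scatter) as a floor and not a size, for compound 2 holds a limit of the assay and not a number: the limit of > 100000 nM in this assay, at which 1 of the 4 values shown sits.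

Open, as far as these compounds go, is how a carboxylic acid, a primary amine or a longer chain in place of the hydroxymethyl would read in the configuration of compound 1. Also open, from the compounds shown here alone, is whether the gap between compound 1 and its two stereoisomers would hold with any of those groups in that place.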